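The source may report more compounds than this note shows. Statements on the series, on what has been measured and on what is new or still open speak of the compounds shown alone.

In a functional assay on PC-3 cells (Homo sapiens) for inhibition, read by MTT assay, with a stated time of 48 h (a higher number here means a weaker inhibitor, a lower number a stronger inhibitor), compound 1 `COc1ccc(-c2coc3cc(OCCCSC(=S)N4CCN(C)CC4)ccc3c2=O)cc1` gives 2210 nM, and compound 2 `COc1ccc(-c2coc3cc(OCCCSC(=S)N4CCCC4)ccc3c2=O)cc1` gives 19400 nM, the higher of the two numbers. Compound 3 `COc1ccc(-c2coc3cc(OCCCCCBr)ccc3c2=O)cc1` is not yet measured. Its difference from compound 2 is a group of 3 heavy atoms (2 carbon, 1 bromine; no ring) in place of a group of 8 heavy atoms (5 carbon, 1 nitrogen, 2 sulfur; one five-membered non-aromatic ring with 1 hetero atom), on a saturated chain carbon, three bonds along the chain from an oxygen on an aromatic ring. Going by the values given here, the only measured step, an 8.8-fold higher number from compound 1 to compound 2 (0.94 log units; beyond the scatter), swapped the group on the thiocarbonyl carbon. That group leaves altogether here, so this step shows that the region can matter but cannot predict the effect of a 2-bromoethyl group. The estimated change, a 1.3-fold higher number from compound 2 to compound 3 (0.11 log units; within the scatter), is expected to be small and toward a higher number. For compound 3, the expected value is 25000 nM, within an estimated range of 8000 nM to 80000 nM.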

Compound 3, half-maximal inhibitory concentration: 44800 nM
Compound 3: the middle estimate sits 1.8-fold (0.25 log units) below what was measured; low and high end bracket the measured number.
By their numbers in this assay, from the lowest: compound 1; then compound 2; then compound 3.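

In this assay, putting 2-bromoethyl in place of the whole group carrying the pyrrolidine ring gives a 2.3-fold higher number from compound 2 to compound 3 (0.36 log units; beyond the scatter) and is a real loss of inhibition. Making the same replacement of the group carrying the 4-methylpiperazine ring gives a 20-fold higher number from compound 1 to compound 3 (1.31 log units; beyond the scatter) and costs more. Among these three, the 2-bromoethyl compound is the weakest inhibitor, and the size of the loss depends on which ring-bearing group leaves. Still open, as far as these compounds go, is how an amine such as dimethylamino, a carboxylic acid or a longer chain would behave on this chain carbon. No available data explain these differences.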